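The source may report more compounds than this note shows. Statements on the series, on what has been measured and on what is new or still open speak of the compounds shown alone.

Compound 1, `COc1cc(CNC(=S)NCC(COC(=O)C(C)(C)C)Cc2ccc(C)c(C)c2)c(Br)cc1O`, gives 19.9 nM in an assay on CHO cells for displacement of a labelled ligand from transient receptor potential cation channel subfamily V member 1 (Rattus norvegicus) (on this read-out higher numbers stand for weaker inhibition and lower numbers for stronger inhibition), and compound 2, `COc1cc(CNC(=S)NCC(COC(=O)C(C)(C)C)Cc2ccc(C)c(C)c2)c(I)cc1O`, gives 18.9 nM in this assay. Their single difference is iodo in place of bromo on an aromatic carbon, and the step of a 1.1-fold lower number from compound 1 to compound 2 (0.02 log units; within the scatter). Compound 3, `COc1cc(CNC(=S)NC(CCc2ccc(C)c(C)c2)COC(=O)C(C)(C)C)c(Br)cc1O`, is built from the same atoms as compound 1 joined differently; the difference between the two cores is not broken down here. In this assay compound 3 gives 109 nM, the highest number among the three measured compounds, with compound 1 and compound 2 both well below it. Compound 4, `COc1cc(CNC(=S)NC(CCc2ccc(C)c(C)c2)COC(=O)C(C)(C)C)c(I)cc1O`, is not yet measured. It differs from compound 3 by iodo in place of bromo on an aromatic carbon, the same change as that between compound 1 and compound 2, at a place described in identical terms. The step from compound 3 to compound 4 is expected to be a 1.0-fold lower number from compound 3 to compound 4 (0.02 log units; within the scatter), resting on the earlier step of a 1.1-fold lower number from compound 1 to compound 2 (0.02 log units; within the scatter), which stayed within the scatter. Compound 4 is accordingly estimated at 105 nM, between 55 nM and 210 nM.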

Compound 4, inhibition constant: 140 nM
Compound 4: the middle estimate sits 1.3-fold (0.12 log units) below what was measured, and the stated range covers the measured number.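

In this assay iodo in place of bromo gives a 1.3-fold higher number from compound 3 to compound 4 (0.11 log units; within the scatter) and this step agrees with the earlier one on the other core: the same change on two cores in this assay, a 1.1-fold lower number (0.02 log units; within the scatter) from compound 1 to compound 2 and a 1.3-fold higher number (0.11 log units; within the scatter) from compound 3 to compound 4, 1.4-fold (0.13 log units) apart, within the scatter of two such steps. On these two cores, then, the exchange carries across as a step within the scatter, so a bromo result served as a fair guide to the iodo partner. Two pairs do not make a rule for other cores, and they show nothing about why the exchange leaves the number in place.

Open, on these data alone, is whether chloro, fluoro or a methyl group on that same aromatic carbon would hold the number as bromo and iodo do. Also open, as far as these compounds go, is whether a hydrogen there would do so on either core.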